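The compounds below may be only part of what the source reports. "The series", "measured", "known", "first", "only" and "open" are said of these compounds alone.

compound 1, `CC(C)CSc1nc(N)nc2c1ncn2/C=C1/CC1(CO)CO`, "not determined" (no result reported)
compound 2, `CCCSc1nc(N)nc2c1ncn2/C=C1/CC1(CO)CO`, > 20000 nM
compound 3, `CCCCCOc1nc(N)nc2c1ncn2/C=C1/CC1(CO)CO`, > 20000 nM

In an ADME assay on MOLT-3 cells (Homo sapiens) for cytotoxicity, with a stated time of 7 days (on this read-out higher numbers stand for lower toxicity in this test and lower numbers for higher toxicity in this test), compound 1 has no number; no result was obtained for it. For compound 2 only a limit is known, > 20000 nM. Compound 3 likewise yields only a limit, > 20000 nM. The step that the two limits leave unreadable from compound 2 to compound 3 therefore cannot be read. Two of the three values sit at the limit of > 20000 nM in this assay, at which 2 of the 3 values shown sit, and nothing in the series gives a numerical foothold.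

Compound 4, `CCCCOc1nc(N)nc2c1ncn2/C=C1/CC1(CO)CO`, differs from compound 1 by butoxy in place of isobutylsulfanyl on an aromatic carbon. Among the measured compounds shown here, no measured step bears on this change, and the single measured step, from compound 2 to compound 3, is itself unreadable. Compound 4 is expected to behave like its neighbours in this assay, with an estimated value of 40000 nM in the range 15000 nM to 120000 nM, most likely reported only as a limit.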

Compound 4, half-maximal cytotoxic concentration: > 20000 nM
Compound 4: a limit, no number (the forecaster's own chance of this, stated with the estimate: 85%); the middle value is on the limit's open side.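

Among the compounds shown here, no step among compound 2, compound 3 and compound 4 can be read in this assay, as all three values are limits: the limit of > 20000 nM in this assay, at which 3 of the 4 values shown sit. On these data alone, whether the propylsulfanyl, pentyloxy and butoxy groups differ at all in this assay stays open.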